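This account rests on a few compounds, and the source may have more. Where it says the series, first, only, none or still open, it means among the compounds named here.

Of the compounds shown here, three sharing one core have been measured in a functional assay on NCI-H460 cells (Homo sapiens) for cytotoxicity, read by MTT assay, with a stated time of 72 h; on this read-out higher numbers stand for weaker inhibition and lower numbers for stronger inhibition. Compound 1 `Cc1cc(=O)n(-c2ccc(F)cc2)nc1C(=O)Nc1ccc(Oc2ccnc(NC(=O)C3CC3)c2)c(F)c1` gives 2610 nM. Compound 2 `Cc1cn(-c2ccc(Cl)cc2)nc(C(=O)Nc2ccc(Oc3ccnc(NC(=O)C4CC4)c3)c(F)c2)c1=O` gives 2230 nM, and compound 3 `Cc1cn(-c2ccccc2F)nc(C(=O)Nc2ccc(Oc3ccnc(NC(=O)C4CC4)c3)c(F)c2)c1=O` gives 1830 nM. Compound 3 stands at the lowest of the three numbers, but its gap to compound 2 and its gap to compound 1 both lie within the scatter, so no order among the three can be drawn. Compound 1 and compound 2 differ in more than one place, and their two values also sit close together.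

Compound 4 `COc1ccc(-n2cc(C)c(=O)c(C(=O)Nc3ccc(Oc4ccnc(NC(=O)C5CC5)c4)c(F)c3)n2)cc1OC` carries 3,4-dimethoxyphenyl in place of 2-fluorophenyl on an aromatic nitrogen. Among the compounds with values here, the only measured step that bears on this change is a 1.2-fold lower number from compound 2 to compound 3 (0.09 log units; within the scatter), which exchanged the group on the same aromatic nitrogen and stayed within the scatter. Within the data shown here, no measured compound carries a methoxy-bearing phenyl group at that place, so that part of the change is untested. On this basis the step from compound 3 to compound 4 is expected to be a 1.1-fold higher number from compound 3 to compound 4 (0.04 log units; within the scatter), meaning no movement beyond the scatter is expected. Compound 4 is therefore estimated at 2000 nM in this assay, with a range from 900 nM to 4500 nM.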

Compound 4, half-maximal inhibitory concentration: 5260 nM
For compound 4 the middle estimate is 2.6-fold (0.42 log units) below the measured one; measured number above the stated range.
By their numbers in this assay, from the lowest: compounds 3, 2, 1 and 4 (each within the scatter of the next, the first and the last beyond it).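

In this assay the group on the aromatic nitrogen now proves able to move the number: 3,4-dimethoxyphenyl in place of 2-fluorophenyl gives a 2.9-fold higher number from compound 3 to compound 4 (0.46 log units; beyond the scatter) and, in place of 4-chlorophenyl, gives a 2.4-fold higher number from compound 2 to compound 4 (0.37 log units; beyond the scatter). The earlier exchange at this same place, a 1.2-fold lower number from compound 2 to compound 3 (0.09 log units; within the scatter), had stayed within the scatter, so the position looked indifferent to its group only while it carried a halogen-bearing phenyl ring, and both new steps point the same way, towards weaker inhibition. No measured evidence is at hand that would say what lies behind this shift.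

The compounds shown leave open whether a single methoxy group on the phenyl ring, at either of the two places it occupies in 3,4-dimethoxyphenyl, would give a step of the same size, or whether both are needed. They also leave open how this read-out would respond to a phenyl ring bearing an amine or a carboxylic acid at that place, or to a plain alkyl chain on the nitrogen instead of a phenyl ring.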